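This account rests on a few compounds, and the source may have more. Where it says the series, first, only, none or still open, it means among the compounds named here.

Series notes. Compound 1 `CC(c1ccc(C(F)(F)F)cc1)N1CC2(CCN(c3nc(=O)c4cc(C(F)(F)F)cc([N+](=O)[O-])c4s3)CC2)C1`, compound 2 `CC(c1cc(F)c(F)c(F)c1)N1CC2(CCN(c3nc(=O)c4cc(C(F)(F)F)cc([N+](=O)[O-])c4s3)CC2)C1` and compound 3 `CC(c1ccc(Cl)c(F)c1)N1CC2(CCN(c3nc(=O)c4cc(C(F)(F)F)cc([N+](=O)[O-])c4s3)CC2)C1` share one core and differ only in the aryl group on the saturated chain carbon bound to an amine nitrogen in a ring and a saturated chain carbon. In an ADME assay on Vero cells (Chlorocebus sabaeus) for cytotoxicity (on this read-out lower numbers stand for higher toxicity in this test and higher numbers for lower toxicity in this test), compound 1 reaches only the limit of the test, > 64 ug/mL. Compound 2 likewise stops at a limit in this assay, with > 64 ug/mL. Compound 3 also gives a limit in this assay, > 64 ug/mL. Due to the limit of > 64 ug/mL in this assay, at which 3 of the 3 values shown sit, the three steps among these compounds carry no readable size: a step that the two limits leave unreadable from compound 1 to compound 2, a step that the two limits leave unreadable from compound 1 to compound 3 and a step that the two limits leave unreadable from compound 2 to compound 3. Where compound 3 stands is thus known only as this limit, and the two further values in the set are limits as well.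

Compound 4 `CC(c1ccc(OC(F)(F)F)cc1)N1CC2(CCN(c3nc(=O)c4cc(C(F)(F)F)cc([N+](=O)[O-])c4s3)CC2)C1` differs from compound 3 by a single change: 4-(trifluoromethoxy)phenyl in place of 4-chloro-3-fluorophenyl on a saturated chain carbon bound to an amine nitrogen in a ring and a saturated chain carbon. Within the data shown here, no measured step bears on this change with a readable size, since the three steps measured so far all end at the limit. The expectation for compound 4 in this assay is therefore again a limit rather than a number, and the step that the limit leaves unreadable from compound 3 to compound 4 is expected to be unreadable in the same way. Compound 4 is estimated at 80 ug/mL, within 45 ug/mL to 160 ug/mL.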

Compound 4, half-maximal cytotoxic concentration: > 64 ug/mL
Compound 4: only a limit was reported (the forecaster's own chance of this, stated with the estimate: 85%); the middle value does not contradict the limit.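

No new step can be read between compound 4 and compound 1, compound 2 or compound 3 in this assay, because each of these values is a limit and not a number: the limit of > 64 ug/mL in this assay, at which 4 of the 4 values shown sit.

The compounds shown leave open whether the aryl groups on the shared core differ at all in this assay, and at what concentration any of them becomes cytotoxic.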